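Hydroxy for hydrogen on the shared core of compound 2

A few compounds are considered here, and "the series" means these few. Any claim that something is new, unique, unknown or untested is made for them only; others in the source may bear on it.

Measured compounds in an assay for binding affinity to Neuronal acetylcholine receptor; alpha4/beta2 (Rattus norvegicus); a lower number here means a stronger inhibitor, a higher number a weaker inhibitor:
- compound 1 `COc1ccc(-c2cnc3cc4c(cc3n2)C2CNCC4C2)cc1`: 26 nM
- compound 2 `c1cnc2cc3c(cc2c1)C1CNCC3C1`: 1.6 nM
- compound 3 `c1ccc(-c2cnc3cc4c(cc3c2)C2CNCC4C2)cc1`: 132 nM

Compound 2 gives the lowest number of the three in this assay; compound 1 stands nearest to it and compound 3 furthest. Compound 4 `Oc1ccc2cc3c(cc2n1)C1CNCC3C1` is the unmeasured member. The change from compound 2 to compound 4 is hydroxy in place of hydrogen on an aromatic carbon, placed on an aromatic carbon of a six-membered aromatic ring with one nitrogen, next to the ring nitrogen.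

Going by the values given here, only one measured step touches the same position of the core: an 83-fold higher number from compound 2 to compound 3 (1.92 log units; beyond the scatter). That step puts a large ring group where the hydroxy group of compound 4 will sit, and it weakened binding strongly. A single-atom hydroxy group is a far smaller addition, so the same direction is expected, but a weaker step. Compound 1 carries its methoxyphenyl group on a core with a second ring nitrogen and gives 26 nM, which does not bear directly on the hydroxy change.

Compound 4 is therefore expected to show a modest loss, a 5.0-fold higher number from compound 2 to compound 4 (0.70 log units; beyond the scatter), with an estimated value of 8 nM in the range 2 nM to 40 nM.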

Compound 4, inhibition constant: 8.5 nM
Compound 4: the middle estimate sits 1.1-fold (0.03 log units) below what was measured; the range from low to high includes it.
By their numbers in this assay, from the lowest: compound 2; then compound 4; then compound 1; then compound 3.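

In this assay, a hydroxy on the aromatic carbon next to the ring nitrogen is tolerated only at a cost: a 5.3-fold higher number from compound 2 to compound 4 (0.73 log units; beyond the scatter). This modest step, still beyond the scatter, shows that even a single added heavy atom registers on the shared core, yet it remains far smaller than the large step for phenyl at its own site, an 83-fold higher number from compound 2 to compound 3 (1.92 log units; beyond the scatter). No evidence on why the hydroxy raises the number is available.

As far as these compounds go, whether the loss follows hydroxy itself or any replacement of hydrogen on this carbon remains open; a methoxy group, an amine or a chlorine atom there would give the direct comparison. Also open, from the compounds shown here alone, is whether a hydroxy on another aromatic carbon of the shared core would give a step of similar size.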